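The source may report more compounds than this note shows. Statements on the series, on what has been measured and on what is new or still open speak of the compounds shown alone.

Measured compounds:
compound 1 `CCCCC#Cc1c(C)[nH]c2ccc(OC)cc2c1=O` gives 5.25 in a physicochemical assay for lipophilicity, at pH 7.4; on this read-out higher numbers stand for higher lipophilicity and lower numbers for lower lipophilicity
compound 2 `CCCCC#Cc1c(C)[nH]c2ccc(Cl)cc2c1=O` gives 2.98 in this assay
compound 3 `COc1cccc2c(=O)c(Cc3ccccc3)c(C)[nH]c12` gives 2.24 in this assay

Compound 1 and compound 2 differ in one place: chloro in place of methoxy on an aromatic carbon. This change made a step of a number 2.27 log units lower from compound 1 to compound 2 (beyond the scatter). Compound 3 stands lowest of the three measured compounds; how its core differs from the core of compound 1 is not broken down here. Compound 4 `Cc1[nH]c2c(Cl)cccc2c(=O)c1Cc1ccccc1` is not yet measured. It differs from compound 3 by chloro in place of methoxy on an aromatic carbon. This is the same kind of change as from compound 1 to compound 2, but the place is not identical: in compound 2 the chloro sits meta to a fused ring and para to a fused ring, whereas in compound 4 it sits ortho to a fused ring and meta to a fused ring. Resting only on the single measured step from compound 1 to compound 2, a step of a number 1.04 log units lower from compound 3 to compound 4 (beyond the scatter) is expected in this assay, with wide uncertainty. Compound 4 is therefore estimated at 1.2, between -0.3 and 2.8.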

Compound 4, distribution coefficient: 2.78
Compound 4: the middle estimate sits 1.58 log units below what was measured, and the stated range covers the measured number.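

In this assay, chloro in place of methoxy on an aromatic carbon made a step of a number 0.54 log units higher from compound 3 to compound 4 (beyond the scatter) on the core of compound 3, whereas the same kind of change made a step of a number 2.27 log units lower from compound 1 to compound 2 (beyond the scatter) on the core of compound 1. The change therefore did not keep its direction across these two pairs, but the pairs differ in both core and place, so they cannot show which of the two matters. Nothing shown gives a reason for the difference between the two steps.

On these data alone, what remains open is how an amine or a carboxylic acid on that aromatic carbon would read on either core. Also open, as far as these compounds go, is whether chloro and methoxy would give the same kind of step at one identical place on both cores.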